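Benzyl for Phenoxy on the Distal Aromatic Ring

A few compounds are considered here, and "the series" means these few. Any claim that something is new, unique, unknown or untested is made for them only; others in the source may bear on it.

For the measured compounds named here, in an assay on cells for activation of probable G-protein coupled receptor 34 (Mus musculus), with a stated time of 1 h (a lower number here means a smaller maximal response, a higher number a larger maximal response), compound 3 `N[C@@H](COP(=O)(O)OCCCOC(=O)CCc1ccccc1OCc1cccc(Oc2ccccc2)c1)C(=O)O` gives 0.48, the highest of the three numbers measured so far; compound 2 `N[C@@H](COP(=O)(O)OCCCOC(=O)CCc1ccccc1OCCCCCCOc1ccccc1)C(=O)O` gives 0.071 and compound 1 `CCCCCCCCCCCOc1ccccc1CCC(=O)OCCCOP(=O)(O)OC[C@H](N)C(=O)O` gives 0.04, both lying beyond the scatter below it. Compound 4 `N[C@@H](COP(=O)(O)OCCCOC(=O)CCc1ccccc1OCc1cccc(Cc2ccccc2)c1)C(=O)O` differs from compound 3 by benzyl in place of phenoxy on an aromatic carbon. Going by the values given here, the one measured step, a number 0.031 higher from compound 1 to compound 2 (within the scatter), concerns a change on a saturated chain carbon and so says nothing about an exchange on the aromatic ring. Among the compounds with values here, no measured step bears on this change. Resting on compound 3 alone, the step expected for compound 4 is a number 0.030 lower from compound 3 to compound 4 (within the scatter), none beyond the scatter. Compound 4 is therefore estimated at 0.45, with a range from 0.22 to 0.68.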

Compound 4, intrinsic activity: the largest response reached, as a fraction of the reference agonist's: 0.077
Estimate against measurement, compound 4: 0.37 above; the whole stated range lies above it.
By their numbers in this assay, from the lowest: compounds 1, 2 and 4 (each within the scatter of the next); then compound 3.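

In this assay, for the compounds shown here, benzyl in place of phenoxy on this aromatic carbon gives a number 0.40 lower from compound 3 to compound 4 (beyond the scatter), the first large step. The two groups have the same count of heavy atoms and each carries one six-membered aromatic ring of carbon only, so the maximal response here is sensitive to an exchange that removes one oxygen and one hydrogen-bond acceptor. No measurement shown accounts for the size of this step. The compounds shown leave open whether an amine, a thioether or a carbonyl in place of the phenoxy oxygen would keep the response of compound 3.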